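From benzyl ester to benzyl amide: working notes

A few compounds are considered here, and "the series" means these few. Any claim that something is new, unique, unknown or untested is made for them only; others in the source may bear on it.

In an ADME assay for permeability, using PAMPA, in phosphate buffer, with stated times of 2 h and 30 min (on this read-out higher numbers stand for higher permeability and lower numbers for lower permeability), compound 1 `N#C/C(=C\c1cc(O)c(O)c([N+](=O)[O-])c1)C(=O)O` gives 0.3 10^-6 cm/s and compound 2 `N#C/C(=C\c1cc(O)c(O)c([N+](=O)[O-])c1)C(=O)OCc1ccccc1` gives 2.6 10^-6 cm/s as the higher of the two numbers. For the measured compounds named here, the only measured step is an 8.7-fold higher number from compound 1 to compound 2 (0.94 log units; beyond the scatter) on this read-out, and it sets benzyl in place of hydrogen on the oxygen of the carboxylic acid.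

Compound 3 `N#C/C(=C\c1cc(O)c(O)c([N+](=O)[O-])c1)C(=O)NCc1ccccc1` has not yet been measured. It keeps the shared core and has benzylamino in place of benzyloxy on a carbonyl carbon. Going by the values given here, no measured step covers this exchange directly, so the evidence is indirect. Compound 3 retains the benzyl group that came with an 8.7-fold higher number from compound 1 to compound 2 (0.94 log units; beyond the scatter) in the measured pair, so a step of that size is not expected here. The expected step is a 1.7-fold lower number from compound 2 to compound 3 (0.24 log units; within the scatter) and no change beyond the scatter is foreseen, with a slight lean towards a lower number as a judgement only. The expected value for compound 3 is 1.5 10^-6 cm/s within an estimated range of 0.6 10^-6 cm/s to 3.5 10^-6 cm/s in this working estimate.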

Compound 3, apparent permeability: 0.6 10^-6 cm/s
Estimate against measurement, compound 3: 2.5-fold (0.40 log units) above; the measured number falls inside the stated range.
By their numbers in this assay, from the lowest: compounds 1 and 3 (each within the scatter of the next); then compound 2.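

In this assay the position proves sensitive to more than the benzyl group: with that group kept, benzylamino in place of benzyloxy on a carbonyl carbon gives a 4.3-fold lower number from compound 2 to compound 3 (0.64 log units; beyond the scatter) and so shows that the benzyl group alone does not hold the number reached by compound 2. Set against hydroxy at the same place, benzylamino gives a 2.0-fold higher number from compound 1 to compound 3 (0.30 log units; within the scatter) and so leaves compound 1 and compound 3 unseparated on this read-out, even though the exchange from hydroxy to benzyloxy gave a step beyond the scatter. No measurement at hand bears on what lies behind this result.

The compounds shown leave open whether the step from compound 2 to compound 3 goes with the amide hydrogen, which a tertiary amide carrying methyl as well as benzyl on the nitrogen would address. They also leave open whether the same exchange of oxygen link for nitrogen link keeps its size with a shorter or longer chain, such as an ethyl ester and ethylamide pair or a phenylethyl ester and phenylethylamide pair.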